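The compounds below may be only part of what the source reports. "The series", "measured", "known", "first", "only" and "open" are said of these compounds alone.

Measured compounds in an ADME assay on L02 cells (Homo sapiens) for cytotoxicity, read by MTT assay, with a stated time of 24 h; a higher number here means a weaker inhibitor, a lower number a stronger inhibitor:

Compound 1, `O=C1/C(=C/c2cccnc2)CN(S(=O)(=O)c2ccccc2)C/C1=C\c1ccccc1F`, gives 15300 nM.
Compound 2, `Cc1ccc(S(=O)(=O)N2C/C(=C\c3cccnc3)C(=O)/C(=C/c3ccccc3F)C2)cc1`, gives 14900 nM.
Compound 3, `O=C1/C(=C/c2ccncc2)CN(S(=O)(=O)c2ccccc2)C/C1=C\c1ccccc1C(F)(F)F`, gives 12300 nM.

Compound 1 and compound 2 differ by one change, (methyl in place of hydrogen on an aromatic carbon), and the step measured for it is a 1.0-fold lower number from compound 1 to compound 2 (0.01 log units; within the scatter). Compound 4, `Cc1ccc(S(=O)(=O)N2C/C(=C\c3ccncc3)C(=O)/C(=C/c3ccccc3C(F)(F)F)C2)cc1`, is not yet measured in this assay. It differs from compound 3 by methyl in place of hydrogen on an aromatic carbon, the same change in the same place as that between compound 1 and compound 2. The difference between the core of compound 3 and the core of compound 1 is not broken down here. Going by the values given here, because the one measured instance of this change gave a 1.0-fold lower number from compound 1 to compound 2 (0.01 log units; within the scatter), the step from compound 3 to compound 4 is expected to be about as small, a 1.0-fold lower number from compound 3 to compound 4 (0.01 log units; within the scatter). Compound 4 is therefore estimated at 12000 nM in this assay, expected to fall between 7000 nM and 21000 nM.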

Compound 4, half-maximal inhibitory concentration: 12800 nM
For compound 4 the middle estimate is 1.1-fold (0.03 log units) below the measured one; low and high end bracket the measured number.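

In this assay the change from phenylsulfonyl to (4-methylphenyl)sulfonyl gives a 1.0-fold higher number from compound 3 to compound 4 (0.02 log units; within the scatter), and set beside the earlier step it shows no difference between the two cores: the same change on two cores in this assay, a 1.0-fold lower number (0.01 log units; within the scatter) from compound 1 to compound 2 and a 1.0-fold higher number (0.02 log units; within the scatter) from compound 3 to compound 4, 1.1-fold (0.03 log units) apart, within the scatter of two such steps. So on these two cores the methyl gives a step that cannot be told from the scatter, and the two steps agree. Two pairs do not show that the change would carry equally to other cores, and with steps this small they show only that the methyl is tolerated here, not what it does in any other setting.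

The compounds shown leave open what a larger or different group would do in place of that methyl, such as a methoxy group, an amine or a carboxylic acid. They also leave open whether a longer chain there would give a step beyond the scatter.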